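This account rests on a few compounds, and the source may have more. Where it says the series, first, only, none or still open, it means among the compounds named here.

Measured compounds in an ADME assay on CCRF-HSB-2 cells (Homo sapiens) for cytotoxicity, with a stated time of 7 days; on this read-out lower numbers stand for higher toxicity in this test and higher numbers for lower toxicity in this test:
compound 1, `Nc1nc(NC2CCCCC2)c2ncn(/C=C3/CC3(CO)CO)c2n1` — in this assay compound 1 gives > 20000 nM, a limit of the assay.
compound 2, `Nc1nc(SCc2ccccc2)c2ncn(/C=C3/CC3(CO)CO)c2n1` — in this assay compound 2 gives > 100000 nM, likewise only a limit of the assay.

Compound 2 therefore stands at the upper limit of what this assay reports, with no number of its own; the other value shown is also a limit of > 20000 nM in this assay, at which 1 of the 2 values shown sits (the limit of > 100000 nM in this assay, at which 1 of the 2 values shown sits).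

The change from compound 2 to compound 3, `C=CCOc1nc(N)nc2c1ncn2/C=C1/CC1(CO)CO`, is allyloxy in place of benzylsulfanyl on an aromatic carbon.

Going by the values given here, the one measured step that bears on this position is a step that the two limits leave unreadable from compound 1 to compound 2, and it cannot be read, both ends being limits. Among the compounds with values here, there is thus no measured guide to the size or direction of the step to compound 3; the only anchor is that compound 2 shows no cytotoxicity up to its limit.

For compound 3 the expected step is a step that the limit leaves unreadable from compound 2 to compound 3, that is, no movement beyond the scatter. The estimate for compound 3 in this assay is 150000 nM, with a range from 40000 nM to 500000 nM, most likely reported again only as a limit.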

Compound 3, half-maximal cytotoxic concentration: > 20000 nM
Compound 3 was reported as a limit (the forecaster's own chance of this, stated with the estimate: 85%); the middle value lies beyond the limit too.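

In this assay compound 3 gives > 20000 nM, a limit of the assay. Going by these compounds alone, no step among compound 1, compound 2 and compound 3 can be read, as all three values are limits. Still open is whether cyclohexylamino, benzylsulfanyl and allyloxy on the shared core differ in cytotoxicity at all, and at what concentration any of these compounds would show it.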